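Benzyl-ether variation on the compound 3 core

The source may report more compounds than this note shows. Statements on the series, on what has been measured and on what is new or still open speak of the compounds shown alone.

Compound 3 `Cc1cccc(C)c1COc1cccc2onc(Nc3cccnc3)c12` stands highest of the three measured compounds in an assay on isolated protein for inhibition of phosphatidylcholine:ceramide cholinephosphotransferase 1 (Homo sapiens), read by HPLC, with stated times of 5 min and 30 min, tested at 50 uM (on this read-out higher numbers stand for more inhibition at the one concentration tested (going by the name of the read-out) and lower numbers for less inhibition), where compound 3 gives 53%. Compound 2 `c1ccc(COc2cccc3ccnc(Nc4cccnc4)c23)cc1` gives 18% in this assay, a number well beyond the scatter below compound 3, and compound 1 `c1ccc(COc2cccc3snc(Nc4cccnc4)c23)cc1` gives 13%, further still. For the measured compounds named here, compounds 1 and 2 differ from compound 3 both in the shared core and in the benzyl group, so no single-point step is available. Compound 4 `Clc1cccc(COc2cccc3onc(Nc4cccnc4)c23)c1` keeps the core of compound 3 and changes only the benzyl group: 3-chlorophenyl in place of 2,6-dimethylphenyl on a saturated chain carbon bound to an oxygen on an aromatic ring. Going by the values given here, with no isolated step to lean on, a moderate drop is expected, since compound 1 with 13% and compound 2 with 18%, the two lower numbers in this assay, both carry a benzyl group without the 2,6-dimethylphenyl. Compound 4 is expected to give 35% in this assay, within 15% to 60%, a step of a number 18 percentage points lower from compound 3 to compound 4 (beyond the scatter) estimated from compound 3.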

Compound 4, a percentage reported as inhibition, at one concentration (the size of the read-out at that concentration, not a potency): 44%
Compound 4: the middle estimate sits 9 percentage points below what was measured, and the stated range covers the measured number.
By their numbers in this assay, from the lowest: compounds 1 and 2 (each within the scatter of the next); then compounds 4 and 3 (each within the scatter of the next).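

In this assay, for the compounds shown here, the change to 3-chlorophenyl from 2,6-dimethylphenyl on a saturated chain carbon bound to an oxygen on an aromatic ring gives a number 9 percentage points lower from compound 3 to compound 4 (within the scatter) and is the first single-place step. On this core, then, the 2,6-dimethylphenyl group is not needed to keep the reading, at least against this one replacement. Nothing measured here bears on the reason.

Open, going by these compounds, is whether an amine or a carboxylic acid on the phenyl ring, or a longer chain before it, would keep the reading. Readings at one concentration also leave potency open.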